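Piperazin-1-yl for pyridin-2-yl: working notes on the series

This account rests on a few compounds, and the source may have more. Where it says the series, first, only, none or still open, it means among the compounds named here.

Measured so far in a functional assay on HepG2 cells (Homo sapiens) for inhibition, read by MTT assay, with a stated time of 72 h; a lower number here means a stronger inhibitor, a higher number a weaker inhibitor:
- compound 1 `CC(C)(C)n1cc2c(n1)C(=O)CC1(CCN(C(=O)c3cc(-c4ccc(Cl)cc4)nc4ccccc34)CC1)O2` gives 630 nM
- compound 2 `CC(C)(C)n1cc2c(n1)C(=O)CC1(CCN(C(=O)c3cc(-c4ccccn4)nc4ccccc34)CC1)O2` gives 1500 nM

Going by the values given here, of the two numbers, the higher belongs to compound 2 (1500 nM), and its only measured neighbour is compound 1 (630 nM). The next compound, compound 3 `CC(C)(C)n1cc2c(n1)C(=O)CC1(CCN(C(=O)c3cc(N4CCNCC4)nc4ccccc34)CC1)O2`, is not yet measured. It differs from compound 2 as follows: piperazin-1-yl in place of pyridin-2-yl on an aromatic carbon. The new group therefore sits on an aromatic carbon next to the ring nitrogen, in place of pyridin-2-yl.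

Among the compounds with values here, only one measured step bears on this place: a 2.4-fold higher number from compound 1 to compound 2 (0.38 log units; beyond the scatter). That step is modest and exchanges one aromatic ring for another. Within the data shown here, no measured compound carries a non-aromatic ring here, so it is only a loose guide to direction or size. In this assay, a modest change at most is the working expectation, with a slight lean towards a higher number. The expected step is a 1.2-fold higher number from compound 2 to compound 3 (0.08 log units; within the scatter), so no clear move beyond the scatter is anticipated. The estimated value for compound 3 is 1800 nM (expected range 500 nM to 6000 nM).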

Compound 3, half-maximal inhibitory concentration: 8570 nM
Compound 3: the middle estimate sits 4.8-fold (0.68 log units) below what was measured, outside the stated range (above it).
By their numbers in this assay, from the lowest: compound 1; then compound 2; then compound 3.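

In this assay, this place on an aromatic carbon next to the ring nitrogen proves more sensitive than the exchange of one aromatic ring for another suggested: piperazin-1-yl gives a 5.7-fold higher number from compound 2 to compound 3 (0.76 log units; beyond the scatter), and the comparison with the 4-chlorophenyl compound gives a 14-fold higher number from compound 1 to compound 3 (1.13 log units; beyond the scatter). Going by these compounds alone, compound 3 is thus the weakest of the three, and this is the first sign that a six-membered non-aromatic ring with 2 hetero atoms is poorly accepted here, although the group keeps the 6 heavy atoms of pyridin-2-yl and differs from it in ring type, hetero atoms and its 1 hydrogen-bond donor. Nothing available bears on which of these differences accounts for the loss.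

The compounds shown do not separate ring type from the free ring amine hydrogen, so it remains open whether morpholin-4-yl or 4-methylpiperazin-1-yl would stay closer to compound 2 in this assay. Phenyl without the chlorine is also absent, which leaves unclear how much of the standing of compound 1 belongs to the chlorine and how much to the aromatic ring itself.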